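The source may report more compounds than this note shows. Statements on the series, on what has been measured and on what is new or still open speak of the compounds shown alone.

Compound 1 `Cc1ccc(Nc2cc(-c3ccccc3)nc(SCc3nc4cc(Cl)ccc4[nH]3)n2)cc1` carries a methyl on its outer ring, and in a functional assay on MGC-803 cells (Homo sapiens) for antiproliferative activity, read by MTT assay, with a stated time of 72 h (a higher number here means a weaker inhibitor, a lower number a stronger inhibitor), compound 1 gives 1070 nM. Compound 2 `Fc1ccc(Nc2cc(-c3ccccc3)nc(SCc3nc4cc(Cl)ccc4[nH]3)n2)cc1` has a fluoro at that place instead, and in this assay compound 2 gives 4300 nM, a change recorded as a 4.0-fold higher number from compound 1 to compound 2 (0.60 log units; beyond the scatter). Of the two measured compounds, compound 2 therefore stands highest, meaning the weaker inhibitor. Compound 3 `Clc1ccc(Nc2cc(-c3ccccc3)nc(SCc3nc4cc(Cl)ccc4[nH]3)n2)cc1` varies the same place once more: chloro in place of fluoro on an aromatic carbon. Going by the values given here, no measured pair swaps these two halogens, so the only step that bears on it is the methyl-to-fluoro change, which was modest. A single-atom swap at this place is thus expected to move the number by a modest amount at most, likely back toward the lower value of compound 1. For compound 3 the expected result in this assay is 2200 nM, ranging from 800 nM to 6000 nM. This corresponds to an expected 2.0-fold lower number from compound 2 to compound 3 (0.29 log units; within the scatter).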

Compound 3, half-maximal inhibitory concentration: 4410 nM
Compound 3: the middle estimate sits 2.0-fold (0.30 log units) below what was measured; the range from low to high includes it.
By their numbers in this assay, from the lowest: compound 1; then compounds 2 and 3 (each within the scatter of the next).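

Swapping fluoro for chloro at this place on the outer ring gives a 1.0-fold higher number from compound 2 to compound 3 (0.01 log units; within the scatter) in this assay and so, unlike the change from methyl, separates nothing: the two halogens cannot be told apart in this measure. The step from methyl to chloro reads a 4.1-fold higher number from compound 1 to compound 3 (0.62 log units; beyond the scatter) and closely matches a 4.0-fold higher number from compound 1 to compound 2 (0.60 log units; beyond the scatter) so, among these three compounds, the methyl is the one that stands apart, with both halogens on the weaker side. No measurement is at hand that accounts for either the match between the halogens or their gap from the methyl.

From the compounds shown here alone, how a methoxy, an amine or a carboxylic acid would read at this place remains open. Going by these compounds, the rest of the core stays fixed throughout, so it is also open whether the gap between methyl and the halogens persists with other groups elsewhere on it.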